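Removing a Protecting Group at the Far End

This account rests on a few compounds, and the source may have more. Where it says the series, first, only, none or still open, it means among the compounds named here.

Compound 3 `CC(C)(C)OC(=O)N1CC[C@H](C(=O)N2CCC(NS(=O)(=O)c3cc(S(=O)(=O)c4ccccc4)ccc3C(F)(F)F)CC2)C1` is measured in an assay on U2OS cells for inhibition of secreted frizzled-related protein 1 (Homo sapiens), read by a luciferase reporter, with a stated time of 18 h (on this read-out lower numbers stand for an effect already at smaller amounts and higher numbers for an effect only at larger amounts of compound), at 150 nM. Among the three numbers in hand it stands highest, yet the other two lie close: compound 1 `O=C(c1cccnc1)N1CCC(NS(=O)(=O)c2cc(S(=O)(=O)c3ccccc3)ccc2C(F)(F)F)CC1` gives 120 nM and compound 2 `O=C(O)c1ccc(S(=O)(=O)N2CCC(NS(=O)(=O)c3cc(S(=O)(=O)c4ccccc4)ccc3C(F)(F)F)CC2)cc1` gives 110 nM, and both steps, a 1.3-fold higher number from compound 1 to compound 3 (0.10 log units; within the scatter) and a 1.1-fold lower number from compound 1 to compound 2 (0.04 log units; within the scatter), stay within the scatter. Compound 4 `O=C([C@H]1CCNC1)N1CCC(NS(=O)(=O)c2cc(S(=O)(=O)c3ccccc3)ccc2C(F)(F)F)CC1` differs from compound 3 in one place: hydrogen in place of tert-butoxycarbonyl on an amine nitrogen in a ring, so the five-membered ring keeps only a plain hydrogen on its nitrogen. Within the data shown here, no measured step removes exactly this group. The two steps that bear on it both alter the same outer part of the shared core, one exchanging a pyridin-3-yl for the whole tert-butoxycarbonyl-bearing ring, the other exchanging a carbonyl-linked pyridine for a sulfonyl-linked carboxyphenyl, and neither moved the number beyond the scatter. The expected step is therefore no change at the digits printed from compound 3 to compound 4 (within the scatter), with no change beyond the scatter. Compound 4 is estimated at 150 nM, with a range from 60 nM to 400 nM.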

Compound 4, half-maximal effective concentration: 700 nM
For compound 4 the middle estimate is 4.7-fold (0.67 log units) below the measured one; the measured number lies above the stated range.
By their numbers in this assay, from the lowest: compounds 2, 1 and 3 (each within the scatter of the next); then compound 4.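

In this assay, among these compounds, the amine nitrogen of the five-membered ring proves sensitive to what it carries: taking off tert-butoxycarbonyl gives a 4.7-fold higher number from compound 3 to compound 4 (0.67 log units; beyond the scatter), the first step here to pass beyond the scatter. Compound 4 also stands apart from the two other compounds, with a 5.8-fold higher number from compound 1 to compound 4 (0.77 log units; beyond the scatter) and a 6.4-fold higher number from compound 2 to compound 4 (0.80 log units; beyond the scatter), so this outer part of the molecule tolerates large changes among compounds 1, 2 and 3 but not every change. Nothing available explains why the plain hydrogen gives the higher number.

Still open, as far as these compounds go, is whether a methyl or an acetyl on that nitrogen would stay close to compound 3 or to compound 4. That would show whether tert-butoxycarbonyl itself matters or whether any group there in place of hydrogen would do.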